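Benzyl Swap on a Weak Alpha-Glucosidase Scaffold

The source may hold more compounds than are shown below. What is called first, only, known or untested is meant among the compounds shown, and "the series" means these compounds.

This account follows a small set of imide compounds tested in an assay on isolated protein for inhibition of lysosomal alpha-glucosidase (Rattus norvegicus), read by colorimetric assay; on this read-out lower numbers stand for stronger inhibition and higher numbers for weaker inhibition. Compound 1, `Cc1ccc(S(=O)(=O)Nc2ccc3c(c2)C(=O)N(Cc2ccccc2F)C3=O)cc1`, gives 195000 nM in this assay. Compound 2, `O=C1c2ccc([N+](=O)[O-])cc2C(=O)N1CCNc1ccccc1`, gives 111000 nM. Compound 3, `Nc1ccc2c(c1)C(=O)N(CCNc1ccccc1)C2=O`, gives 144000 nM. Compound 1 holds the highest of the three numbers, yet its number and those of compound 2 and compound 3 all sit within the scatter of one another, so no ordering among them can be drawn. Going by the values given here, the only single-point step among the measured compounds is the one from compound 2 to compound 3, with amino in place of nitro on an aromatic carbon, where a 1.3-fold higher number from compound 2 to compound 3 (0.11 log units; within the scatter).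

Compound 4, `Cc1ccc(S(=O)(=O)Nc2ccc3c(c2)C(=O)N(Cc2ccc(Cl)c(Cl)c2)C3=O)cc1`, is not yet measured. It differs from compound 1 only by 3,4-dichlorophenyl in place of 2-fluorophenyl on a saturated chain carbon bound to an amide-type nitrogen in a ring. Among the compounds with values here, no measured step touches that position, and the one step that exists concerns a different part of the core and lies within the scatter. With nothing in the data pointing in either direction, a step of no more than the scatter is expected from compound 1 to compound 4, namely a 1.1-fold lower number from compound 1 to compound 4 (0.06 log units; within the scatter). Compound 4 is therefore estimated at 170000 nM in this assay, with a range from 60000 nM to 500000 nM.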

Compound 4, half-maximal inhibitory concentration: 122000 nM
Beside the measured number, compound 4's estimate is 1.4-fold (0.14 log units) above it; measured number inside the range.
By their numbers in this assay, from the lowest: compounds 2, 4, 3 and 1 (each within the scatter of the next).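

At the saturated chain carbon bound to an amide-type nitrogen in a ring, the only reading among these compounds is a 1.6-fold lower number from compound 1 to compound 4 (0.20 log units; within the scatter) when 3,4-dichlorophenyl replaces 2-fluorophenyl. The position therefore accepts the exchange of 2-fluorobenzyl for 3,4-dichlorobenzyl on the shared core without a step that can be told apart from repeat measurements, so this assay gives no ranking of these two groups, and this single pair cannot show a trend for the position as a whole. No measurement shown here offers an explanation for this small step or for the high numbers that compound 1 and compound 4 share.

Still open, from the compounds shown here alone, is whether a different group at this position, such as an unsubstituted benzyl, a longer chain ending in a phenyl ring, or a chain carrying an amine or a carboxylic acid, would give a step beyond the scatter. Also open, going by these compounds, is whether 3,4-dichlorobenzyl would read the same way on a core bearing the amino group of compound 3 or the nitro group of compound 2 in place of the sulfonamide of compound 1.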